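A few compounds are considered here, and "the series" means these few. Any claim that something is new, unique, unknown or untested is made for them only; others in the source may bear on it.

In a functional assay on Shh Light II cells (Mus musculus) for inhibition, read by a luciferase reporter (a higher number here means a weaker inhibitor, a lower number a stronger inhibitor), compound 1 `O=C(NC1CCC(O)CC1)N1CCC(c2nc(-c3ccc4ccccc4n3)no2)CC1` gives 2700 nM, compound 2 `O=C(OC1CCCCC1)N1CCC(c2nc(-c3ccc4ccccc4n3)no2)CC1` gives 580 nM, and compound 3 `O=C(Nc1ccccc1C(F)(F)F)N1CCC(c2nc(-c3ccc4ccccc4n3)no2)CC1` gives 700 nM. Compound 3 therefore stands level with compound 2, as the step of a 1.2-fold higher number from compound 2 to compound 3 (0.08 log units; within the scatter) shows, and well under compound 1, as the step of a 3.9-fold lower number from compound 1 to compound 3 (0.59 log units; beyond the scatter) shows.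

Compound 4 `COc1ccccc1NC(=O)N1CCC(c2nc(-c3ccc4ccccc4n3)no2)CC1` differs from compound 3 in one place: methoxy in place of trifluoromethyl on an aromatic carbon, ortho to a large group (methoxy in place of trifluoromethyl on an aromatic carbon). Among the measured compounds shown here, no measured step changes a group at this place, so the evidence is only indirect. Replacing the whole group on the carbonyl carbon gave modest steps, a 4.7-fold lower number from compound 1 to compound 2 (0.67 log units; beyond the scatter) and a 3.9-fold lower number from compound 1 to compound 3 (0.59 log units; beyond the scatter), and the step of a 1.2-fold higher number from compound 2 to compound 3 (0.08 log units; within the scatter) stayed within the scatter. A much smaller edit on the aromatic ring is thus expected to leave this assay within the scatter, with no firm direction. The expected step is a 1.1-fold higher number from compound 3 to compound 4 (0.06 log units; within the scatter). For compound 4 the estimated value is 800 nM, with an expected range of 300 nM to 2200 nM.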

Compound 4, half-maximal inhibitory concentration: 410 nM
Compound 4: middle estimate off by 2.0-fold (0.29 log units), on the high side, and the stated range covers the measured number.
By their numbers in this assay, from the lowest: compounds 4, 2 and 3 (each within the scatter of the next); then compound 1.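

In this assay, this first direct change at the aromatic position shows that methoxy can take the place of trifluoromethyl without moving the number beyond the scatter (a 1.7-fold lower number from compound 3 to compound 4 (0.23 log units; within the scatter)), although the entering group carries a hydrogen-bond acceptor that the leaving group lacks. The 2-methoxyphenyl compound also stays level with the cyclohexyloxy compound (a 1.4-fold lower number from compound 2 to compound 4 (0.15 log units; within the scatter)), whereas the step from the 4-hydroxycyclohexyl compound is modest and beyond the scatter (a 6.6-fold lower number from compound 1 to compound 4 (0.82 log units; beyond the scatter)), so compound 1 remains apart from the other three. No independent evidence bears on this result.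

The compounds shown leave open how a hydrogen atom, a chlorine atom or a hydroxyl group would read at this place on the aromatic ring. They also do not tell whether a dimethylamino group there would stay within the scatter of compound 3 and compound 4.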